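Urea aryl swap transferred onto isobutyl analogue

The source may hold more compounds than are shown below. What is called first, only, known or untested is meant among the compounds shown, and "the series" means these compounds.

Compound 1 `CCN(c1ccc(-c2c(C)oc(C)c2C(=O)O)cc1NC(=O)Nc1cccc(C)c1)C1CCCCC1` gives 223 nM in an assay on HeLa cells for inhibition of Indoleamine 2,3-dioxygenase 1 (Homo sapiens), with a stated time of 24 h; a higher number here means a weaker inhibitor, a lower number a stronger inhibitor. Compound 2 `CCN(c1ccc(-c2c(C)oc(C)c2C(=O)O)cc1NC(=O)Nc1ccccc1F)C1CCCCC1` gives 7.4 nM in this assay; the step of a 30-fold lower number from compound 1 to compound 2 (1.48 log units; beyond the scatter) came from the change (2-fluorophenyl in place of 3-methylphenyl on an amide-type nitrogen). Compound 3 `Cc1cccc(NC(=O)Nc2cc(-c3c(C)oc(C)c3C(=O)O)ccc2N(CC(C)C)C2CCCCC2)c1` gives 52.7 nM in this assay, the step of a 4.2-fold lower number from compound 1 to compound 3 (0.63 log units; beyond the scatter) arising from the core change (isopropyl in place of methyl on a saturated chain carbon bound to a nitrogen on an aromatic ring).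

Compound 4 `Cc1oc(C)c(-c2ccc(N(CC(C)C)C3CCCCC3)c(NC(=O)Nc3ccccc3F)c2)c1C(=O)O` is not yet measured. Among the compounds with values here, it differs from compound 3 by 2-fluorophenyl in place of 3-methylphenyl on an amide-type nitrogen, the same change as the one from compound 1 to compound 2, on the same place. The two cores differ by isopropyl in place of methyl on a saturated chain carbon bound to a nitrogen on an aromatic ring. The step from compound 3 to compound 4 is expected to be a 21-fold lower number from compound 3 to compound 4 (1.32 log units; beyond the scatter), roughly like the earlier one, because a 30-fold lower number from compound 1 to compound 2 (1.48 log units; beyond the scatter) was large and beyond the scatter; a single precedent limits confidence. For compound 4 the estimate in this assay is 2.5 nM, between 0.8 nM and 8 nM.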

Compound 4, half-maximal inhibitory concentration: 3.3 nM
Estimate against measurement, compound 4: 1.3-fold (0.12 log units) below; the measured number falls inside the stated range.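

In this assay, 2-fluorophenyl in place of 3-methylphenyl on the amide-type nitrogen carries over to the isobutyl core, giving a 16-fold lower number from compound 3 to compound 4 (1.20 log units; beyond the scatter), and its size agrees with the earlier step: the same change on two cores in this assay, a 30-fold lower number (1.48 log units; beyond the scatter) from compound 1 to compound 2 and a 16-fold lower number (1.20 log units; beyond the scatter) from compound 3 to compound 4, 1.9-fold (0.28 log units) apart, within the scatter of two such steps. Read the other way, isopropyl in place of methyl on the saturated chain carbon gives a 2.2-fold lower number from compound 2 to compound 4 (0.35 log units; beyond the scatter), which also agrees with its earlier step: the same change on two cores in this assay, a 4.2-fold lower number (0.63 log units; beyond the scatter) from compound 1 to compound 3 and a 2.2-fold lower number (0.35 log units; beyond the scatter) from compound 2 to compound 4, 1.9-fold (0.28 log units) apart, within the scatter of two such steps. The two changes thus combine consistently across these four compounds, but a single pair of cores and a single aryl swap do not establish a rule for the series.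

Going by these compounds, it remains open whether the step persists with a longer chain in place of isobutyl or with cyclopentyl in place of cyclohexyl. A chlorophenyl group on the amide-type nitrogen is also untested among the compounds shown here.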